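Swapping the ester oxygen for sulfur in a terpenoid ester

The compounds below may be only part of what the source reports. "The series", "measured", "known", "first", "only" and "open" are said of these compounds alone.

Measured compounds:
- compound 1 `CC(/C=C/CC(C)CCCC(C)C)=C\C(=O)OC(C)(C)C`: 7.56
- compound 2 `COC(C)(C)CCCC(C)C/C=C/C(C)=C/C(=O)OC(C)(C)C`: 6.36
- compound 3 `CCOC(=O)/C=C(C)/C=C/CC(C)CCCC(C)(C)OC(C)=O`: 5.57

In a physicochemical assay for lipophilicity (a lower number here means a more polar compound, a higher number a more lipophilic compound), compound 1 gives 7.56, the highest of the three numbers. Compound 2 comes nearest, and compound 3 lies furthest away. The only single-point step among these is a number 1.20 log units lower from compound 1 to compound 2 (beyond the scatter).

Compound 4 `C=CCSC(=O)/C=C(C)/C=C/CC(C)CCCC(C)C` has not yet been measured in this assay. It differs from compound 1 as follows: allylsulfanyl in place of tert-butoxy on a carbonyl carbon. Among the measured compounds shown here, none of the measured steps mirrors this exchange; the step from compound 1 to compound 2 concerns a methoxy on the saturated chain and bears on it only in showing how large a single change can be here. For the measured compounds named here, with no direct precedent, the account rests on the shape of the change itself: a smaller group enters, but it brings sulfur in place of oxygen. The expected step is therefore small, a number 0.14 log units higher from compound 1 to compound 4 (within the scatter), and may not exceed the scatter. The estimate for compound 4 is 7.7, with a range from 7.1 to 8.3.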

Compound 4, partition coefficient: 7.97
Compound 4: the middle estimate sits 0.27 log units below what was measured; measured number inside the range.
By their numbers in this assay, from the lowest: compound 3; then compound 2; then compound 1; then compound 4.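

In this assay, the exchange of tert-butoxy for allylsulfanyl on the carbonyl carbon gives a number 0.41 log units higher from compound 1 to compound 4 (beyond the scatter), so a change at this place can move the number clear of the scatter. Among the compounds shown here, the direction differs from that of the only earlier single-place step, a number 1.20 log units lower from compound 1 to compound 2 (beyond the scatter), which lay on the saturated chain, and here the number rises even though the entering group has fewer heavy atoms than the one that leaves. No measurement at hand accounts for this step.

The exchange alters the heteroatom and the carbon part of the group together, and the compounds shown leave open how much of the step belongs to each. Allyloxy or tert-butylsulfanyl on the same carbonyl carbon would separate the two parts.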